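The compounds below may be only part of what the source reports. "The series", "measured", "known", "first", "only" and "open" are said of these compounds alone.

Working notes on the series, starting from compound 1 `CCn1c(N)c(-c2nc3ccccc3[nH]2)c2nc(C#N)c(C#N)nc21`. In a functional assay on K562 cells (Homo sapiens) for antiproliferative activity, read by MTT assay, with a stated time of 48 h (on this read-out higher numbers stand for weaker inhibition and lower numbers for stronger inhibition), compound 1 gives > 50000 nM, which is a limit and not a number. In this assay compound 2 `N#Cc1nc2c(-c3nc4ccccc4[nH]3)c(N)n(CCCO)c2nc1C#N` gives > 50000 nM, again only a limit. Compound 2 therefore has no readable position, and both measured compounds stand at the limit of > 50000 nM in this assay, at which 2 of the 2 values shown sit.

Compound 3 `CCN(CC)CCCCn1c(N)c(-c2nc3ccccc3[nH]2)c2nc(C#N)c(C#N)nc21` changes the chain of compound 2: (diethylamino)methyl in place of hydroxy on a saturated chain carbon, three bonds along the chain from an aromatic nitrogen. Cut one bond further out, the same difference reads 3-hydroxypropyl to 4-(diethylamino)butyl.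

Going by the values given here, the only measured step is a step that the two limits leave unreadable from compound 1 to compound 2, so it offers no size to carry over to this change. Among the compounds with values here, no measured compound carries the (diethylamino)methyl group either. With compound 2 at a limit, a readable value in this assay could only lie on the side of stronger inhibition, so any step is expected in that direction, though its size remains poorly constrained. A result at the same limit remains quite possible. The expected change is an at least 2.5-fold lower number from compound 2 to compound 3 (0.39 log units; beyond the scatter). Compound 3 is estimated at 20000 nM, with an expected range of 3000 nM to 50000 nM.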

Compound 3, half-maximal inhibitory concentration: 1440 nM
Beside the measured number, compound 3's estimate is 14-fold (1.14 log units) above it, and the stated range ends above it.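

Going by these compounds alone, replacing the chain of the earlier compounds with 4-(diethylamino)butyl gives the first readable value of the series in this assay: the change from 3-hydroxypropyl is an at least 34-fold lower number from compound 2 to compound 3 (1.54 log units; beyond the scatter), and the step from the shorter unsubstituted chain is an at least 34-fold lower number from compound 1 to compound 3 (1.54 log units; beyond the scatter). Both sizes are lower bounds, and the step between the two earlier compounds cannot be read, so these compounds gave no sign that the substituent on this aromatic nitrogen could move the read-out at all; compound 3 shows that it can, and by a large margin. The two earlier compounds still supply only a limit as their reference: the limit of > 50000 nM in this assay, at which 2 of the 3 values shown sit.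

The change from compound 2 to compound 3 alters the terminal group and the chain length together, so the compounds shown leave open whether the diethylamino group, the longer chain or the two in combination carry the step. A 4-hydroxybutyl chain and a 3-(diethylamino)propyl chain would separate these contributions, and a piperidine or morpholine at the end of the same chain would test how much depends on the diethylamino group itself.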